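The compounds below may be only part of what the source reports. "The series", "measured", "known", "first", "only" and "open" are said of these compounds alone.

Measured in a functional assay on MCF7 cells (Homo sapiens) for cytotoxicity, read by sulforhodamine B assay, with a stated time of 48 h; on this read-out higher numbers stand for weaker inhibition and lower numbers for stronger inhibition:

compound 1, `CCc1ccccc1OS(=O)(=O)c1ccc(NC(=O)NCCCCl)cc1`, 15000 nM
compound 2, `Cc1ccccc1NS(=O)(=O)c1cccc(NC(=O)NCCCCl)c1`, 52000 nM
compound 3, `CCNC(=O)Nc1ccc(S(=O)(=O)Oc2ccccc2CC)cc1`, 3400 nM

Compound 2 gives the highest number of the three in this assay, beyond the scatter from both compound 1 and compound 3. Compound 3 differs from compound 1 by one change, (hydrogen in place of chloromethyl on a saturated chain carbon, two bonds along the chain from an amide-type nitrogen), and that change brought a 4.4-fold lower number from compound 1 to compound 3 (0.64 log units; beyond the scatter). The difference between the core of compound 1 and the core of compound 2 is not broken down here.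

Compound 4, `CCNC(=O)Nc1cccc(S(=O)(=O)Nc2ccccc2C)c1`, has not yet been measured in this assay. It stands to compound 2 as compound 3 stands to compound 1: the change is hydrogen in place of chloromethyl on a saturated chain carbon, two bonds along the chain from an amide-type nitrogen, the same change at the same place. On the core of compound 1 that change gave a 4.4-fold lower number from compound 1 to compound 3 (0.64 log units; beyond the scatter), and the expectation for compound 4 rests on that single step; nothing shows whether the core of compound 2 answers it in the same way. A step of about the same size is expected from compound 2, that is a 4.3-fold lower number from compound 2 to compound 4 (0.64 log units; beyond the scatter). Compound 4 is therefore estimated at 12000 nM in this assay, with a likely range from 4000 nM to 36000 nM.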

Compound 4, half-maximal inhibitory concentration: 108000 nM
For compound 4 the middle estimate is 9.0-fold (0.95 log units) below the measured one; the measured number lies above the stated range.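

In this assay, replacing chloromethyl with hydrogen, which lowered the number on the core of compound 1, raised it on the core of compound 2, giving a 2.1-fold higher number from compound 2 to compound 4 (0.32 log units; beyond the scatter). The change therefore does not carry over between these two cores, not even in its direction: the same change on two cores in this assay, a 4.4-fold lower number (0.64 log units; beyond the scatter) from compound 1 to compound 3 and a 2.1-fold higher number (0.32 log units; beyond the scatter) from compound 2 to compound 4, 9.2-fold (0.96 log units) apart, beyond the scatter of two such steps

Within the data shown here, this rests on a single pair for each core, so it shows only that the step cannot be transferred from one of these cores to the other; it does not show which feature of the cores sets the direction, or how any further core would respond.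

The compounds shown do not separate the several differences between the two cores, so it remains open which of them goes with the reversal. Also open, as far as these compounds go, is how either core would respond if a hydroxyl group, an amine or a longer chain stood in place of the chloromethyl.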